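The source may hold more compounds than are shown below. What is called first, only, known or untested is meant among the compounds shown, and "the series" means these compounds.

Series notes. Compound 2 `Cc1nc2cc(C(=O)NCc3ccc(F)cc3S(C)(=O)=O)nn2c(-c2cc(F)c3c(c2C)CCCO3)c1[C@H](OC(C)(C)C)C(=O)O` is one of two amide variants on the shared core; compound 1 `Cc1cc(CNC(=O)c2cc3nc(C)c([C@H](OC(C)(C)C)C(=O)O)c(-c4cc(F)c5c(c4C)CCCO5)n3n2)ccc1F` carries the other amide. In an ADME assay on MT2 cells (Homo sapiens) for cytotoxicity (a higher number here means that more compound is tolerated, a lower number that less compound is tolerated), compound 2 gives > 40000 nM, which is a limit of the assay rather than a number. In this assay compound 1 likewise gives only a limit, > 40000 nM. The step that the two limits leave unreadable from compound 1 to compound 2 cannot be read because of the limit of > 40000 nM in this assay, at which 2 of the 2 values shown sit. Compound 3 `Cc1nc2cc(C(=O)NCCC(C)(C)C)nn2c(-c2cc(F)c3c(c2C)CCCO3)c1[C@H](OC(C)(C)C)C(=O)O` differs by neopentyl in place of 4-fluoro-2-(methylsulfonyl)phenyl on a saturated chain carbon bound to an amide-type nitrogen. For the measured compounds named here, no measured step bears on this change, and both values so far sit at the limit, so compound 3 is expected to remain there too, a step of a number no higher from compound 2 to compound 3 (the limit leaves the size open). The estimate for compound 3 is 40000 nM, with a range of 20000 nM to 80000 nM.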

Compound 3, half-maximal cytotoxic concentration: > 40000 nM
Compound 3 ended at the assay's limit (the forecaster's own chance of this, stated with the estimate: 85%); the middle value lies on the limit itself.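

No step among compound 1, compound 2 and compound 3 can be read, because all three give only a limit: the limit of > 40000 nM in this assay, at which 3 of the 3 values shown sit.

Left open is where each compound's actual cytotoxic concentration lies, and whether the amide group shifts it at all.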